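Replacing a Nitro Group on a Biaryl Naphthol

A few compounds are considered here, and "the series" means these few. Any claim that something is new, unique, unknown or untested is made for them only; others in the source may bear on it.

Compound 1 `O=[N+]([O-])c1ccc(-c2ccc3c(O)cccc3c2)cc1`: in an assay for binding affinity to 17-beta-hydroxysteroid dehydrogenase type 2 (Homo sapiens), with a stated time of 20 min, tested at 1 uM (on this read-out higher numbers stand for more inhibition at the one concentration tested (going by the name of the read-out) and lower numbers for less inhibition), compound 1 gives 13%.
Compound 2 `Oc1cccc2cc(-c3cncnc3)ccc12`: compound 2 gives < 10%, which is a limit of the assay and not a number.

Compound 1 thus holds the only number shown; the other value sits at a limit, (the limit of < 10% in this assay, at which 1 of the 2 values shown sits). Compound 3 `CNS(=O)(=O)c1ccc(-c2ccc3c(O)cccc3c2)cc1` differs from compound 1 by methylsulfamoyl in place of nitro on an aromatic carbon. Going by the values given here, no step between measured compounds is available, so no shift beyond the usual scatter is expected, and the step is estimated at a number 1 percentage points lower from compound 1 to compound 3 (within the scatter). Compound 3 is expected to give 12%, between 0% and 25%.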

Compound 3, a percentage reported as inhibition, at one concentration (the size of the read-out at that concentration, not a potency): 57%
For compound 3 the middle estimate is 45 percentage points below the measured one; measured number above the stated range.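

On the aromatic carbon para to a large group, the group carried matters: in this assay, methylsulfamoyl in place of nitro gives a number 44 percentage points higher from compound 1 to compound 3 (beyond the scatter) on the shared core. Going by these compounds alone, this is the first step between measured compounds, and it shows that a change at this position can move the read-out beyond the scatter. Nothing shown accounts for the size of this step.

As far as these compounds go, it remains open whether the step belongs to methylsulfamoyl as a whole or to one of its parts. A carboxylic acid, a primary sulfonamide or an amide at this position would bear on that question.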